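The compounds below may be only part of what the source reports. "The series", "measured", "known", "first", "only" and "open" are said of these compounds alone.

Measured compounds:

compound 1, `CC1=C(C(=O)Nc2ccc(F)cc2)C(c2ccc([N+](=O)[O-])cc2)N=C(SCc2ccccc2Cl)N1`: 1.5%
compound 2, `CC1=C(C(=O)Nc2ccc(F)cc2)C(c2ccc([N+](=O)[O-])cc2)N=C(SCc2cccc(Cl)c2)N1`: 2.1%
compound 3, `COc1ccc(C2N=C(SCc3ccccc3Cl)NC(C)=C2C(=O)Nc2ccc(Br)cc2)cc1`: 3.1%

All three numbers come from a functional assay on the whole organism (artery, strain albino) with Rattus norvegicus as the target, with a stated time of 15 min, at a dose of 10 mg/kg by the oral route; a higher number here means more inhibition at the dose given (going by the name of the read-out), a lower number less inhibition. In this assay compound 1 gives 1.5%, compound 2 gives 2.1% and compound 3 gives 3.1%. Compound 1 and compound 2 share a core and differ in one place: 3-chlorophenyl in place of 2-chlorophenyl on a saturated chain carbon bound to a sulfur. That change made a step of a number 0.6 percentage points higher from compound 1 to compound 2 (within the scatter), so the two values cannot be told apart. The difference between the core of compound 1 and the core of compound 3 is not broken down here; what can be said is that their two values lie within the scatter of each other.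

Compound 4, `COc1ccc(C2N=C(SCc3cccc(Cl)c3)NC(C)=C2C(=O)Nc2ccc(Br)cc2)cc1`, has not yet been measured in this assay. It differs from compound 3 in exactly the same way that compound 2 differs from compound 1: 3-chlorophenyl in place of 2-chlorophenyl on a saturated chain carbon bound to a sulfur. The place of the change is described in the same words for both pairs, so this is the same change on a different core. Because the earlier step was a number 0.6 percentage points higher from compound 1 to compound 2 (within the scatter), the step from compound 3 to compound 4 is expected to be small as well, estimated at a number 0.4 percentage points higher from compound 3 to compound 4 (within the scatter). On that basis compound 4 is expected to give about 3.5% in this assay, with a likely range from 0% to 9%. That expectation rests on one pair only, so it is an estimate, not a rule.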

Compound 4, a percentage reported as inhibition, in the whole organism at one dose (the size of the read-out at that dose, not a potency): 3.1%
The estimate for compound 4 lay 0.4 percentage points above the measured number; low and high end bracket the measured number.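

In this assay, putting 3-chlorophenyl in place of 2-chlorophenyl on a saturated chain carbon bound to a sulfur made no change at the digits printed from compound 3 to compound 4 (within the scatter). Set beside the earlier result, the change reads the same on both cores, with no sign that the core alters its outcome: the same change on two cores in this assay, a number 0.6 percentage points higher (within the scatter) from compound 1 to compound 2 and no change at the digits printed (within the scatter) from compound 3 to compound 4, 0.6 percentage points apart, within the scatter of two such steps

Going by these compounds alone, this shows only that the swap leaves no measurable mark on either of these two cores, and it does not show that a real effect of the change carries from one core to the other, since neither step stands clear of the scatter and there is no effect to follow. Two pairs are also too few to support a rule for the whole series, and the agreement says nothing about cores beyond these two.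

All the compounds shown carry a chlorobenzyl group on the sulfur, so it remains open whether a different group in that place, such as an amine, a carboxylic acid or a longer chain, would move the number in this assay. Also open is whether any of these compounds would stand apart from the others at a different dose.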